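Methoxy in place of bromo on the cinnamate ester

The source may report more compounds than this note shows. Statements on the series, on what has been measured and on what is new or still open speak of the compounds shown alone.

Measured compounds:
compound 1 `COc1cc(OC)c(OC)cc1/C=C/COC(=O)/C=C/c1c(OC)ccc(OC)c1OC` — 50%
compound 2 `COc1cc(OC)c(OC)cc1/C=C/COC(=O)/C=C/c1ccc(Br)cc1` — 25%
compound 3 `COc1cc(OC)c(OC)cc1/C=C/COC(=O)/C=C/c1cc(OC)c(OC)c(OC)c1` — 25%

Three esters of the same core have been tested in a functional assay on the whole organism (strain Kunming) with Mus musculus as the target, with a stated time of 0.5 h, at a dose of 300 mg/kg by the intraperitoneal route; a higher number here means a weaker effect of the compound at the dose given, a lower number a stronger effect. Compound 1 gives 50%, the highest number of the three. Compound 2 gives 25%, level with compound 3 at the digits shown, and the two together form the lowest pair; compound 3 gives 25%. Between compound 2 and compound 1 the gap lies beyond the scatter, while between compound 2 and compound 3 there is no change within the scatter.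

Compound 4 `COc1ccc(/C=C/C(=O)OC/C=C/c2cc(OC)c(OC)cc2OC)cc1` has not been measured. It differs from compound 2 by methoxy in place of bromo on an aromatic carbon. Among the compounds with values here, no measured pair shows this change, so the expectation rests on the values of compounds 2 and 3 alone. Since both compound 2 and compound 3 sit at the same level, the step of a number 5 percentage points higher from compound 2 to compound 4 (within the scatter) in this assay is expected to be small, with no clear direction beyond the scatter. Compound 4 is therefore estimated at 30%, within a range from 15% to 50%.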

Compound 4, a percentage reported as activity, at one dose (the size of the read-out at that dose, not a potency): 0%
Compound 4: the middle estimate sits 30 percentage points above what was measured, outside the stated range (below it).
By their numbers in this assay, from the lowest: compound 4; then compounds 2 and 3 (each within the scatter of the next); then compound 1.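

In this assay the change from 4-bromophenyl to 4-methoxyphenyl produces a number 25 percentage points lower from compound 2 to compound 4 (beyond the scatter), so the group on this aromatic carbon, para to a large group, clearly affects the read-out. The earlier compounds shown here could not show this, as none of them formed a pair differing in one place. No measurement is available that explains the step.

The compounds shown leave open whether the step is particular to methoxy or would also appear with a hydroxyl, an amine or a carboxylic acid on the same carbon. They also leave open whether the same change would produce a step of similar size at other doses, as the read-out here comes from a single dose and does not give a potency.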